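Swapping hydroxy for fluoro on a ring of compound 1

This account rests on a few compounds, and the source may have more. Where it says the series, first, only, none or still open, it means among the compounds named here.

Compound 1 `Cc1nc(C)c(/C=C/C(=O)/C=C/c2ccc(O)cc2)nc1C` gives 4010 nM
Compound 2 `COc1cc(/C=C/C(=O)/C=C/c2nc(C)c(C)nc2C)ccc1O` gives 2190 nM
Compound 3 `COc1cccc(/C=C/C(=O)/C=C/c2nc(C)c(C)nc2C)c1O` gives 2850 nM

In a functional assay on A549 cells (Homo sapiens) for antiproliferative activity, read by MTT assay, with a stated time of 72 h (on this read-out lower numbers stand for stronger inhibition and higher numbers for weaker inhibition), compound 1 gives 4010 nM as its value. That number lies within the usual scatter of the values of compound 2 and compound 3, so the three cannot be ranked with any confidence.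

The unmeasured compound 4 `Cc1nc(C)c(/C=C/C(=O)/C=C/c2ccc(F)cc2)nc1C` keeps the core of compound 1 and differs in one place, where 4-hydroxyphenyl becomes 4-fluorophenyl. The difference is fluoro in place of hydroxy on an aromatic carbon and it amounts to fluoro in place of hydroxy on an aromatic carbon.

Among the compounds with values here, only one measured step bears on this, and only loosely. The step of a 1.8-fold lower number from compound 1 to compound 2 (0.26 log units; within the scatter) adds methoxy in place of hydrogen on an aromatic carbon and stays within the scatter. All three measured compounds carry a hydroxy, so none of them shows what happens when it leaves. The data therefore give no direction, and no step beyond the scatter can be argued for.

The estimated step is a 1.0-fold lower number from compound 1 to compound 4 (0.00 log units; within the scatter) and it is expected to be small, though with real uncertainty on either side. For compound 4 the expected value is 4000 nM with an estimated range from 1600 nM to 10000 nM in this assay.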

Compound 4, half-maximal inhibitory concentration: 5900 nM
For compound 4 the middle estimate is 1.5-fold (0.17 log units) below the measured one; the range from low to high includes it.
By their numbers in this assay, from the lowest: compounds 2, 3, 1 and 4 (each within the scatter of the next, the first and the last beyond it).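

Within the data shown here, compound 4 is the first compound here that lacks the hydroxy, so it gives the first direct reading of what happens when that group leaves its place on the aromatic ring, para to a large group. In this assay the swap gives a 1.5-fold higher number from compound 1 to compound 4 (0.17 log units; within the scatter), so replacing a group counted with a hydrogen-bond donor and acceptor by one counted with neither produces no step beyond the scatter at this position. Nothing available here offers an explanation for this result.

The compounds shown leave open whether this tolerance extends to other groups at the same position, such as an amine, a carboxylic acid, a longer chain such as butoxy, or plain hydrogen, any of which could give a clearer step than fluoro does. They also leave open whether the same swap would give a similar result on compound 2 or compound 3, where a methoxy also sits on the ring, since this single pair speaks only for the core of compound 1.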